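The source may hold more compounds than are shown below. What is called first, only, known or untested is meant among the compounds shown, and "the series" means these compounds.

Compound 1 `Nc1nc(NCc2ccccc2)c2ncn(/C=C3/CC3(CO)CO)c2n1`: > 20000 nM in an ADME assay on MOLT-3 cells (Homo sapiens) for cytotoxicity, with a stated time of 7 days (on this read-out lower numbers stand for higher toxicity in this test and higher numbers for lower toxicity in this test), a limit of the assay.
Compound 2 `Nc1nc2c(ncn2/C=C2/CC2(CO)CO)c(=O)[nH]1`: > 20000 nM in this assay, a limit of the assay.

Compound 1 stands where both shown values stand, at the limit of > 20000 nM in this assay, at which 2 of the 2 values shown sit. No number for it in this assay is available, only this limit. Compound 3 `CCCCCCSc1nc(N)nc2c1ncn2/C=C1/CC1(CO)CO` differs from compound 1 in one place: hexylsulfanyl in place of benzylamino on an aromatic carbon. Going by the values given here, no measured step between two compounds is available to guide the change. For this assay the step from compound 1 to compound 3 is expected to be none beyond the usual scatter, a step that the limit leaves unreadable from compound 1 to compound 3. Compound 3 is therefore estimated at 25000 nM, most likely between 8000 nM and 80000 nM, and the assay may again report only a limit.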

Compound 3, half-maximal cytotoxic concentration: > 20000 nM
Compound 3: a limit, no number; the forecaster's own chance of this, stated with the estimate: 75%; the middle value is on the limit's open side.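

Going by these compounds alone, no step from compound 1 to compound 3 can be read, because both values are limits of the assay: the limit of > 20000 nM in this assay, at which 3 of the 3 values shown sit. The compounds shown leave open whether hexylsulfanyl and benzylamino differ at all in this assay, since none gives a number.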